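Ethoxy to methoxy: from compound 3 to compound 4

The compounds below may be only part of what the source reports. "The series", "measured", "known", "first", "only" and "open" are said of these compounds alone.

Measured in a functional assay on MCF7 cells (Homo sapiens) for antiproliferative activity, read by MTT assay, with a stated time of 48 h; a higher number here means a weaker inhibitor, a lower number a stronger inhibitor 
- compound 1 `COc1ccc(/C=C/C=C\c2cc(OC)c(OC)c(OC)c2)cc1O` gives 75 nM 
- compound 2 `CCOc1cc(-c2ccc3cc[nH]c3c2)cn2c(-c3cc(OC)c(OC)c(OC)c3)nnc12` gives 334 nM 
- compound 3 `CCOc1cc(-c2ccc3[nH]ccc3c2)cn2c(-c3cc(OC)c(OC)c(OC)c3)nnc12` gives 284 nM 

On these numbers, compound 3 stands level with compound 2, while compound 1 lies clearly lower than both. Compound 4 `COc1cc(-c2nnc3c(OC)cc(-c4ccc5[nH]ccc5c4)cn23)cc(OC)c1OC` differs from compound 3 by one change (hydrogen in place of methyl on a saturated chain carbon bound to an oxygen on an aromatic ring), which reads as ethoxy to methoxy. Among the compounds with values here, no measured step covers this change. The only one, a 1.2-fold lower number from compound 2 to compound 3 (0.07 log units; within the scatter), exchanges 1H-indol-6-yl for 1H-indol-5-yl and so bears on it only indirectly. With so little to go on, no step beyond the scatter is expected in this assay, in either direction. The expected step is a 1.0-fold lower number from compound 3 to compound 4 (0.01 log units; within the scatter). The estimate for compound 4 is 280 nM, with an expected range from 120 nM to 650 nM.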

Compound 4, half-maximal inhibitory concentration: 80 nM
Estimate against measurement, compound 4: 3.5-fold (0.54 log units) above, outside the stated range (below it).
By their numbers in this assay, from the lowest: compounds 1 and 4 (each within the scatter of the next); then compounds 3 and 2 (each within the scatter of the next).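

In this assay, cutting ethoxy to methoxy gives a step beyond the scatter (a 3.6-fold lower number from compound 3 to compound 4 (0.55 log units; beyond the scatter)). The position therefore responds to the loss of one methyl, a sensitivity the earlier exchange of 1H-indol-6-yl for 1H-indol-5-yl did not show, as that step stayed within the scatter (a 1.2-fold lower number from compound 2 to compound 3 (0.07 log units; within the scatter)). No measurement offered here accounts for the size of this step. As far as these compounds go, whether a longer chain such as propoxy, or an amine in place of the ethoxy group, would lower the number further remains open. So does whether the same change would carry over to the 1H-indol-6-yl series.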